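The source may report more compounds than this note shows. Statements on the series, on what has been measured and on what is new or still open speak of the compounds shown alone.

Compound 3 `Cc1nc2c3ccccc3ccc2c2nc3c(ccc4ccccc43)c(-c3nccnc3N)c12` gives the lowest number of the three measured compounds in a functional assay on HCT-116 cells (Homo sapiens) for cytotoxicity, read by MTT assay, with a stated time of 48 h (on this read-out higher numbers stand for weaker inhibition and lower numbers for stronger inhibition), at 3560 nM. Compound 1 `Cc1nc2c3ccccc3ccc2c2nc3c(ccc4ccccc43)c(-c3cccc([N+](=O)[O-])c3)c12` gives 13200 nM, and compound 2 `Cc1nc2c3ccccc3ccc2c2nc3c(ccc4ccccc43)c(-c3cccnc3)c12` gives 34200 nM. Compound 4 `COc1ccc(-c2c3ccc4ccccc4c3nc3c2c(C)nc2c4ccccc4ccc32)cc1` differs from compound 3 by 4-methoxyphenyl in place of 3-aminopyrazin-2-yl on an aromatic carbon. The same position has already been varied: the steps of a 3.7-fold lower number from compound 1 to compound 3 (0.57 log units; beyond the scatter) and a 9.6-fold lower number from compound 2 to compound 3 (0.98 log units; beyond the scatter) both exceed the scatter, while a 2.6-fold higher number from compound 1 to compound 2 (0.41 log units; beyond the scatter) is smaller. A higher number is expected for compound 4 because the groups without a hydrogen-bond donor in the steps of a 3.7-fold lower number from compound 1 to compound 3 (0.57 log units; beyond the scatter) and a 9.6-fold lower number from compound 2 to compound 3 (0.98 log units; beyond the scatter) gave the weaker results, so the expected step is a 4.2-fold higher number from compound 3 to compound 4 (0.62 log units; beyond the scatter). Compound 4 is therefore estimated at 15000 nM, within 5000 nM to 45000 nM.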

Compound 4, half-maximal inhibitory concentration: > 80000 nM
Compound 4: no number, only a limit; the forecaster's own chance of this, stated with the estimate: 10%; middle value at least 5.3-fold (0.72 log units) away from the limit.
By their numbers in this assay, from the lowest: compound 3; then compound 1; then compound 2. At a limit, above all of these: compound 4.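

In this assay, compound 4 gives only a limit of the assay, not a number: the limit of > 80000 nM in this assay, at which 1 of the 4 values shown sits. Among these compounds, the steps of an at least 22-fold higher number from compound 3 to compound 4 (1.35 log units; beyond the scatter), an at least 6.0-fold higher number from compound 1 to compound 4 (0.78 log units; beyond the scatter) and an at least 2.3-fold higher number from compound 2 to compound 4 (0.36 log units; beyond the scatter) all lie beyond the scatter, so this position spans a wider range than the earlier compounds showed. The 3-aminopyrazin-2-yl group, the only one here with a hydrogen-bond donor, still gives the lowest number, but that link rests on compound 3 alone.

From the compounds shown here alone, how far compound 4 lies past its limit stays open. So does whether an aminophenyl group, with its amine on a carbon-only ring, would also give a low number.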